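Methyl in place of hydroxy: compound 3 to compound 4

The source may report more compounds than this note shows. Statements on the series, on what has been measured and on what is new or still open speak of the compounds shown alone.

Measured so far in a functional assay on HL-60 cells (Homo sapiens) for cytotoxicity, read by WST assay, with a stated time of 48 h; a lower number here means that less compound is needed, a higher number that more compound is needed for the effect:
- compound 1 `COc1ccc(C[C@H]2COC(=O)[C@@H]2Cc2ccc(Cl)c(Cl)c2)cc1`: 37000 nM
- compound 2 `Cc1ccc(C[C@H]2COC(=O)[C@@H]2Cc2ccc(Cl)c(Cl)c2)cc1`: 19000 nM
- compound 3 `Oc1ccccc1C[C@H]1COC[C@@H]1Cc1ccc(Cl)c(Cl)c1`: 34000 nM

All three values lie within the scatter of one another, so compound 3 at 34000 nM cannot be separated from the other two compounds.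

Compound 4 `Cc1ccccc1C[C@H]1COC[C@@H]1Cc1ccc(Cl)c(Cl)c1` has not yet been measured. It carries methyl in place of hydroxy on an aromatic carbon of compound 3: methyl in place of hydroxy on an aromatic carbon.

Going by the values given here, only one measured step bears on this change: a 1.9-fold lower number from compound 1 to compound 2 (0.29 log units; within the scatter). That step also brings in methyl on an aromatic carbon, but it replaces methoxy rather than hydroxy, and the core of compound 1 differs from that of compound 3. It is therefore only a loose guide. Since it stays within the scatter, no step beyond the scatter is expected in this assay.

The expected step is a 1.3-fold lower number from compound 3 to compound 4 (0.10 log units; within the scatter).

For compound 4 the estimated value is 27000 nM, with an expected range of 13000 nM to 55000 nM.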

Compound 4, half-maximal effective concentration: 21000 nM
The estimate for compound 4 lay 1.3-fold (0.11 log units) above the measured number, and the stated range covers the measured number.
By their numbers in this assay, from the lowest: compounds 2, 4, 3 and 1 (each within the scatter of the next).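

In this assay, the change from 2-hydroxyphenyl to 2-methylphenyl gives a 1.6-fold lower number from compound 3 to compound 4 (0.21 log units; within the scatter), so this position shows no readable response to replacing hydroxy with methyl, even though the hydrogen-bond donor and acceptor counted for hydroxy are absent from methyl. The earlier step, a 1.9-fold lower number from compound 1 to compound 2 (0.29 log units; within the scatter), replaced methoxy on a different core, whereas this step tests methyl directly against hydroxy on the core of compound 3, and it too stays within the scatter. No measurement available here accounts for the size of this step.

As far as these compounds go, whether an amine, a carboxylic acid or a longer chain such as propyl on this aromatic carbon would give a step beyond the scatter remains open. With every value so far within the scatter of its neighbour, the compounds shown do not establish any dependence of this assay on the group at this position.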